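Benzothiophene in place of benzofuran: compound 2 to compound 4

This account rests on a few compounds, and the source may have more. Where it says the series, first, only, none or still open, it means among the compounds named here.

Measured so far, in a functional assay on K562 cells (Homo sapiens) for inhibition, read by trypan blue exclusion, with a stated time of 72 h; a lower number here means a stronger inhibitor, a higher number a weaker inhibitor:
compound 1 `Cn1c(=O)c(S(=O)(=O)c2ccc(F)cc2)cc2cnc(Nc3ccc4occc4c3)nc21` — 5000 nM
compound 2 `Cn1c(=O)c(S(=O)(=O)c2ccc(F)cc2F)cc2cnc(Nc3ccc4occc4c3)nc21` — 15000 nM
compound 3 `COc1ccc(Nc2ncc3cc(S(=O)(=O)c4ccc(C)cc4)c(=O)n(C)c3n2)cc1` — 75000 nM

Compound 2 holds the second highest of the three numbers in this assay. Its nearest neighbour is compound 1, which carries only one fluoro less and gives the lower number; the one-point step is a 3.0-fold higher number from compound 1 to compound 2 (0.48 log units; beyond the scatter), a modest rise beyond the scatter. Going by the values given here, compound 3 sits furthest away with the highest number of the set, but it differs from compound 2 in several places at once, so its value shows only that a differently substituted member of this core can reach a much weaker level.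

Compound 4 `Cn1c(=O)c(S(=O)(=O)c2ccc(F)cc2F)cc2cnc(Nc3ccc4sccc4c3)nc21` is obtained from compound 2 by the change (1-benzothiophen-5-yl in place of 1-benzofuran-5-yl on a nitrogen on an aromatic ring). Among the compounds with values here, no measured pair touches this part of the molecule: the only one-point step in hand, a 3.0-fold higher number from compound 1 to compound 2 (0.48 log units; beyond the scatter), concerns the fluoro on the sulfonyl-bearing aryl and says nothing about the amine-side heteroaryl. Within the data shown here, with no bearing step, the expectation for this assay is no change beyond the scatter, and the step from compound 2 to compound 4 is expected to be no change at the digits printed from compound 2 to compound 4 (within the scatter). Compound 4 is therefore estimated at 15000 nM, within 5000 nM to 45000 nM.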

Compound 4, half-maximal inhibitory concentration: 500 nM
Compound 4: middle estimate off by 30-fold (1.48 log units), on the high side; measured number outside the range, below it.
By their numbers in this assay, from the lowest: compound 4; then compound 1; then compound 2; then compound 3.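

In this assay, 1-benzothiophen-5-yl in place of 1-benzofuran-5-yl on the amine nitrogen gives a 30-fold lower number from compound 2 to compound 4 (1.48 log units; beyond the scatter), so this position responds far more strongly than the fluoro position on the sulfonyl-bearing aryl does in a 3.0-fold higher number from compound 1 to compound 2 (0.48 log units; beyond the scatter). The two groups match in heavy-atom count, ring types, hydrogen-bond donors and acceptors, and net charge, and differ only in the oxygen or sulfur of the five-membered aromatic ring, so a large step here arises from an exchange that leaves all these counts unchanged. Nothing available bears on why the sulfur-containing group gives the lower number.

Whether 1-benzothiophen-5-yl gives a step of similar size on the sulfonyl-bearing aryl of compound 1 remains open, since it is shown only with the aryl of compound 2. Also open, on these data alone, is how far this position tolerates other groups, such as an indolyl group, with nitrogen in the five-membered aromatic ring, or a 1-benzothiophen-5-yl group carrying a carboxylic acid.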